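From 3-nitrophenyl to 4-nitrophenyl: a cytotoxicity estimate

The source may hold more compounds than are shown below. What is called first, only, known or untested is meant among the compounds shown, and "the series" means these compounds.

Compound 1 `CC1=CC[C@@H]([C@@](C)(O)CCCC(C)(C)NC(=S)N/N=C\c2ccc(C)cc2)CC1`: 45300 nM
Compound 2 `CC1=CC[C@@H]([C@@](C)(O)CCCC(C)(C)NC(=S)N/N=C\c2ccc(O)cc2)CC1`: 54400 nM
Compound 3 `CC1=CC[C@@H]([C@@](C)(O)CCCC(C)(C)NC(=S)N/N=C\c2cccc([N+](=O)[O-])c2)CC1`: > 100000 nM (a limit, not a number)

In a functional assay on OVCAR-3 cells (Homo sapiens) for cytotoxicity, read by sulforhodamine B assay (on this read-out lower numbers stand for higher toxicity in this test and higher numbers for lower toxicity in this test), compound 3 stands at the limit of > 100000 nM in this assay, at which 1 of the 3 values shown sits. Compound 4 `CC1=CC[C@@H]([C@@](C)(O)CCCC(C)(C)NC(=S)N/N=C\c2ccc([N+](=O)[O-])cc2)CC1` differs from it by one change: 4-nitrophenyl in place of 3-nitrophenyl on a carbon with a double bond to nitrogen. Within the data shown here, no measured step moves a group on the ring in this way, so the evidence is indirect. Two steps lead to the 3-nitrophenyl group: an at least 2.2-fold higher number from compound 1 to compound 3 (0.34 log units; beyond the scatter), and an at least 1.8-fold higher number from compound 2 to compound 3 (0.26 log units; that floor lies within the scatter). A third step compares the two other compounds: a 1.2-fold higher number from compound 1 to compound 2 (0.08 log units; within the scatter). The 4-nitrophenyl of compound 4 resembles the 4-methylphenyl of compound 1 (45300 nM) and the 4-hydroxyphenyl of compound 2 (54400 nM), so a modest move to a lower number is expected. Another limit is possible for compound 4. The expected change is an at least 1.4-fold lower number from compound 3 to compound 4 (0.15 log units; that floor lies within the scatter). For compound 4 the estimate is 70000 nM, with an expected range of 35000 nM to 130000 nM.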

Compound 4, concentration lethal to 50% of the cells: > 100000 nM
Compound 4: a limit, no number; the forecaster's own chance of this, stated with the estimate: 40%; at least 1.4-fold (0.15 log units) between middle value and limit.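

Compound 4 gives a limit, not a number, so with compound 3 both nitrophenyl compounds now sit at the limit and the step between them cannot be read: the limit of > 100000 nM in this assay, at which 2 of the 4 values shown sit.

Nitro in place of methyl gives an at least 2.2-fold higher number from compound 1 to compound 4 (0.34 log units; beyond the scatter), and nitro in place of hydroxy gives an at least 1.8-fold higher number from compound 2 to compound 4 (0.26 log units; that floor lies within the scatter). The higher number seen with 3-nitrophenyl is therefore not confined to that group, as 4-nitrophenyl also reaches the limit.

As far as these compounds go, how far past the limit compound 3 and compound 4 lie remains unknown, so the two groups cannot be ranked. From the compounds shown here alone, whether an amine or a carboxylic acid in place of the nitro would bring the number back down also remains open.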